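The source may report more compounds than this note shows. Statements on the series, on what has been measured and on what is new or still open speak of the compounds shown alone.

Measured so far:
compound 1 `COc1cc(-n2cccc2C(=O)O)ccc1Nc1ncc(Cl)c(Nc2ccccc2NS(C)(=O)=O)n1` — 1060 nM
compound 2 `COc1cc(-n2cccc2C(=O)N2CCCC2)ccc1Nc1ncc(Cl)c(Nc2ccccc2NS(C)(=O)=O)n1` — 4580 nM

In a functional assay on A549 cells (Homo sapiens) for antiproliferative activity, read by MTT assay, with a stated time of 72 h (on this read-out higher numbers stand for weaker inhibition and lower numbers for stronger inhibition), compound 2 gives 4580 nM, the highest of the two numbers, while compound 1 gives 1060 nM. Among the compounds with values here, the only measured step, a 4.3-fold higher number from compound 1 to compound 2 (0.64 log units; beyond the scatter), ties the pyrrolidin-1-yl amide to a weaker result than the free acid.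

Compound 3 `COc1cc(-n2cccc2C(=O)N2CC(O)C2)ccc1Nc1ncc(Cl)c(Nc2ccccc2NS(C)(=O)=O)n1` differs from compound 2 in one place: 3-hydroxyazetidin-1-yl in place of pyrrolidin-1-yl on a carbonyl carbon. Within the data shown here, no measured pair shows this particular exchange, so the expectation rests on the step from compound 1 to compound 2 alone, which marks the direction in which an amide moved the number. The entering group carries a hydrogen-bond donor and acceptor that the leaving group lacks, which loosely echoes the hydroxy of compound 1, so a partial return toward compound 1 is expected, but only a small one.

Compound 3 is therefore estimated at 2500 nM, within 1000 nM to 6500 nM, a step of a 1.8-fold lower number from compound 2 to compound 3 (0.26 log units; within the scatter).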

Compound 3, half-maximal inhibitory concentration: 2080 nM
Compound 3: middle estimate off by 1.2-fold (0.08 log units), on the high side, and the stated range covers the measured number.
By their numbers in this assay, from the lowest: compounds 1 and 3 (each within the scatter of the next); then compound 2.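

In this assay the exchange of pyrrolidin-1-yl for 3-hydroxyazetidin-1-yl on a carbonyl carbon gives a 2.2-fold lower number from compound 2 to compound 3 (0.34 log units; beyond the scatter) and so shows that amides at this place do not all give the same number. Set against the free acid, the same amide gives a 2.0-fold higher number from compound 1 to compound 3 (0.29 log units; within the scatter) and cannot be told apart from it, so the weaker result of compound 2 does not extend to every amide here. Nothing available explains the change.

The compounds shown leave open whether the hydroxy or the four-membered ring goes with the step from pyrrolidin-1-yl. An azetidin-1-yl amide without the hydroxy and a 3-hydroxypyrrolidin-1-yl amide would separate the two, while a morpholin-4-yl amide would test how far the result reaches.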